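Trimming the alkene side chain of compound 3

A few compounds are considered here, and "the series" means these few. Any claim that something is new, unique, unknown or untested is made for them only; others in the source may bear on it.

- compound 1 `C=C(C)CC[C@]1(C)C2=CCC[C@](C)(C[C@H](O)c3ccoc3)[C@H]2CC[C@H]1C`: 28700 nM
- compound 2 `C=C(C)CC[C@]1(C)C2=CCC[C@](C)(C[C@@H](O)C3=CC(=O)OC3O)[C@H]2CC[C@H]1C`: 3300 nM
- compound 3 `C=C(C)CCC[C@]1(C)C2=CCC[C@](C)(C[C@H](O)C3=CC(=O)OC3O)[C@H]2CC[C@H]1C`: 3000 nM

In a functional assay on HL-60 cells (Homo sapiens) for antiproliferative activity, read by XTT assay, with a stated time of 72 h (on this read-out higher numbers stand for weaker inhibition and lower numbers for stronger inhibition), compound 3 gives 3000 nM and sits level, within the usual scatter, with compound 2 at 3300 nM while compound 1 shows a clearly higher 28700 nM and so weaker inhibition.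

Going on to compound 4 `C=C(C)CC[C@]1(C)C2=CCC[C@](C)(C[C@H](O)C3=CC(=O)OC3O)[C@H]2CC[C@H]1C` puts 1-methylethenyl in place of 2-methylprop-2-en-1-yl on a saturated chain carbon, two bonds along the chain from a saturated ring carbon. Among the compounds with values here, the one measured step, an 8.7-fold lower number from compound 1 to compound 2 (0.94 log units; beyond the scatter), swaps a different group, one that compound 3 and compound 4 share, so it says little about this change. Within the data shown here, no measured pair isolates this chain change on its own.

The closest guide is compound 2, which has the same atoms joined in the same way as compound 4 and differs only in the spatial arrangement at one carbon. Compound 2 gives 3300 nM and that value lies within the scatter of compound 3. In this assay the expected result is therefore no step beyond the scatter, estimated as a 1.1-fold higher number from compound 3 to compound 4 (0.03 log units; within the scatter) here.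

The estimated value for compound 4 is 3200 nM, with an expected range from 1500 nM to 7000 nM.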

Compound 4, half-maximal inhibitory concentration: 3200 nM
For compound 4 middle estimate and measured number coincide at the digits printed, and the stated range covers the measured number.
By their numbers in this assay, from the lowest: compounds 3, 4 and 2 (each within the scatter of the next); then compound 1.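

In this assay, trimming the side chain so that 1-methylethenyl replaces 2-methylprop-2-en-1-yl, on a saturated chain carbon, two bonds along the chain from a saturated ring carbon, gives a 1.1-fold higher number from compound 3 to compound 4 (0.03 log units; within the scatter), so this position tolerates the shorter group with no step beyond the scatter. The stereocentre at a saturated chain carbon, drawn R in compound 2 and S in compound 4, also separates nothing, as a 1.0-fold lower number from compound 2 to compound 4 (0.01 log units; within the scatter) shows, though one limit applies to that reading: the fact that one of compounds 2 and 4 is drawn with a defined configuration and the other without, at the place where they differ. With the side chain of compound 4 and the S drawing in place, the ring group still counts, since exchanging the five-membered aromatic ring of compound 1 for the non-aromatic one gives a 9.0-fold lower number from compound 1 to compound 4 (0.95 log units; beyond the scatter), close in size to an 8.7-fold lower number from compound 1 to compound 2 (0.94 log units; beyond the scatter).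

All the compounds shown keep the double bond in this side chain, so they leave open how a saturated propyl chain, or a chain ending in an amine or a carboxylic acid, would read at this position. Going by these compounds, every value here also comes from this assay, so whether compound 3 and compound 4 stay level in other cells remains open.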